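This account rests on a few compounds, and the source may have more. Where it says the series, first, only, none or still open, it means among the compounds named here.

Three compounds share one core and differ only in the ring on the carbonyl carbon: compound 1 `O=C(C1CCCC1)N1N=CCC1c1ccccc1`, compound 2 `O=C(C1CCC1)N1N=CCC1c1ccccc1` and compound 3 `O=C(C1CCCCC1)N1N=CCC1c1ccccc1`. In a physicochemical assay for lipophilicity, read by HPLC, measured as chromatographic lipophilicity, at pH 7.4 (a higher number here means a more lipophilic compound, a lower number a more polar compound), compound 1 gives 5.4, compound 2 gives 4.7 and compound 3 gives 5.9. Compound 3 therefore holds the highest of the three numbers.

Compound 4 `O=C(c1ccccc1)N1N=CCC1c1ccccc1`, not yet measured, keeps the core and changes that ring: phenyl in place of cyclohexyl on a carbonyl carbon.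

For the measured compounds named here, three measured steps bear on this change, all at the same place. The first, of modest size, is a number 0.70 log units lower from compound 1 to compound 2 (beyond the scatter). The second, also modest, is a number 0.50 log units higher from compound 1 to compound 3 (beyond the scatter). The third, a large one, is a number 1.20 log units higher from compound 2 to compound 3 (beyond the scatter). Going by the values given here, all three exchange one non-aromatic ring for another, and none introduces an aromatic ring, so they offer a scale for the change but no direct precedent. Among the compounds with values here, the data contain no measured compound with phenyl on this carbonyl carbon, and the direction is therefore a judgement with real uncertainty.

On that scale, a modest fall in this assay is expected, clearly smaller than the large step above. The expected change is a number 0.80 log units lower from compound 3 to compound 4 (beyond the scatter). Compound 4 is estimated at 5.1, with an expected range of 4.6 to 5.6.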

Compound 4, distribution coefficient: 4.6
Compound 4: middle estimate off by 0.50 log units, on the high side; low and high end bracket the measured number.
By their numbers in this assay, from the lowest: compounds 4 and 2 (each within the scatter of the next); then compound 1; then compound 3.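

In this assay, phenyl in place of cyclohexyl on the carbonyl carbon leaves the count of heavy atoms, the ring size and the counts of hydrogen-bond donors and acceptors unchanged, yet the step is a number 1.30 log units lower from compound 3 to compound 4 (beyond the scatter), so at this position the number does not follow those counts alone. Across the three earlier compounds the number rose with ring size, from cyclobutyl through cyclopentyl to cyclohexyl, and six-membered phenyl goes against that pattern: the step is a number 0.80 log units lower from compound 1 to compound 4 (beyond the scatter), and the comparison with the smallest ring gives a number 0.10 log units lower from compound 2 to compound 4 (within the scatter). Nothing available here accounts for the difference between the aromatic and the non-aromatic six-membered ring.

The compounds shown leave open whether a pyridyl or thienyl ring on the carbonyl carbon would follow phenyl, and how far a fluorine or a methoxy group on the phenyl would shift the number in this assay. They also leave open whether an open chain such as isopropyl or tert-butyl would fall in line with the non-aromatic rings.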